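Swapping chloro for cyano on the benzyl ether: cytotoxicity

The compounds below may be only part of what the source reports. "The series", "measured", "known", "first", "only" and "open" are said of these compounds alone.

Compound 1 `O=c1c(O)c(-c2ccccc2)oc2cc(OCc3ccccc3Cl)cc(O)c12`: in an ADME assay on Huh-5-2 cells (Homo sapiens) for cytotoxicity, read by WST assay, with a stated time of 3 days (on this read-out higher numbers stand for lower toxicity in this test and lower numbers for higher toxicity in this test), compound 1 gives > 100000 nM, which is a limit of the test rather than a number.
Compound 2 `N#Cc1ccccc1COc1cc(O)c2c(=O)c(O)c(-c3ccccc3)oc2c1`: in this assay compound 2 gives 22000 nM.
Compound 3 `O=c1c(O)c(-c2ccccc2)oc2cc(OCc3ccc(Cl)cc3)cc(O)c12`: in this assay compound 3 gives > 100000 nM, again only a limit.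

Compound 3 thus sits at the limit, as does compound 1; compound 2 alone carries a read number. Compound 4 `N#Cc1ccc(COc2cc(O)c3c(=O)c(O)c(-c4ccccc4)oc3c2)cc1` differs from compound 3 by cyano in place of chloro on an aromatic carbon. The same swap in the other pair gave an at least 4.5-fold lower number from compound 1 to compound 2 (0.65 log units; beyond the scatter), and likewise an at least 4.5-fold higher number from compound 2 to compound 3 (0.65 log units; beyond the scatter). Both point the same way, so an at least modest step toward a lower number is expected, though the limit for compound 3 hides its true size. Compound 4 is expected near 40000 nM, between 12000 nM and 100000 nM, an expected step of an at least 2.5-fold lower number from compound 3 to compound 4 (0.39 log units; beyond the scatter).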

Compound 4, half-maximal cytotoxic concentration: 94000 nM
Compound 4: the middle estimate sits 2.4-fold (0.37 log units) below what was measured; low and high end bracket the measured number.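

Compound 4 gives a second read number, so the place of the cyano group can be compared directly: in this assay the change is a 4.3-fold higher number from compound 2 to compound 4 (0.63 log units; beyond the scatter). Cyano in place of chloro at this place gives an at least 1.0-fold lower number from compound 3 to compound 4 (0.02 log units; that floor lies within the scatter), and the change from the 2-chlorophenyl group gives an at least 1.0-fold lower number from compound 1 to compound 4 (0.02 log units; that floor lies within the scatter), so neither floor shows a real drop. The same swap therefore cannot yet be called stronger at one place than at the other: the same change on two cores in this assay, an at least 4.5-fold lower number (0.65 log units; beyond the scatter) from compound 1 to compound 2 and an at least 1.0-fold lower number (0.02 log units; that floor lies within the scatter) from compound 3 to compound 4; the limit leaves it open whether they differ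

From the compounds shown here alone, what an amine or a carboxylic acid in place of the cyano group would do stays open.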